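Furan to Thiophene on the Saturated Ring Carbon

This account rests on a few compounds, and the source may have more. Where it says the series, first, only, none or still open, it means among the compounds named here.

In an assay on membranes from HeLa cells for displacement of a labelled ligand from adenosine receptor A3 (Homo sapiens), read by scintillation counting, with a stated time of 180 min, tested at 1 uM (a lower number here means less inhibition, a higher number more inhibition at the concentration tested (going by the name of the read-out)), compound 1 `CC(=O)C1=C(C)NC(=O)NC1c1ccsc1` gives 1%, while compound 2 `CCN(CC)C(=O)C1=C(C)NC(=O)NC1c1ccsc1` gives 35%, a step of a number 34 percentage points higher from compound 1 to compound 2 (beyond the scatter). Compound 3 `CC1=C(C(=O)OCC2CCC2)C(c2ccco2)NC(=O)N1` gives 1%, level with compound 1 and together with it the lowest of the three numbers, far beneath compound 2. Compound 4 `CC1=C(C(=O)OCC2CCC2)C(c2ccsc2)NC(=O)N1` differs from compound 3 by a single exchange: thiophen-3-yl in place of furan-2-yl on a saturated ring carbon. For the measured compounds named here, no measured step covers this exchange; the one measured step concerns the group on the carbonyl carbon, which compounds 3 and 4 share. Compound 1, which carries thiophen-3-yl, sits as low as compound 3 with its furan-2-yl. Compound 4 is therefore expected to stay near the floor, a number 2 percentage points higher from compound 3 to compound 4 (within the scatter), with an estimate of 3% ranging from -6% to 14%.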

Compound 4, a percentage reported as inhibition, at one concentration (the size of the read-out at that concentration, not a potency): 2%
Compound 4: middle estimate off by 1 percentage points, on the high side; measured number inside the range.
By their numbers in this assay, from the lowest: compounds 1, 3 and 4 (each within the scatter of the next); then compound 2.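

With cyclobutylmethoxy kept on the carbonyl carbon, thiophen-3-yl in place of furan-2-yl on the saturated ring carbon gives a number 1 percentage points higher from compound 3 to compound 4 (within the scatter) in this assay. With thiophen-3-yl kept, cyclobutylmethoxy in place of diethylamino gives a number 33 percentage points lower from compound 2 to compound 4 (beyond the scatter), whereas in place of methyl it gives a number 1 percentage points higher from compound 1 to compound 4 (within the scatter), so among these three groups on the carbonyl carbon only diethylamino stands apart. Nothing available explains either result. As far as these compounds go, it stays open whether the ring exchange would matter with diethylamino on the carbonyl carbon, and whether an amine on the saturated ring carbon would change the number.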